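Ethyl on the sulfonamide nitrogen: compound 3 to compound 4

A few compounds are considered here, and "the series" means these few. Any claim that something is new, unique, unknown or untested is made for them only; others in the source may bear on it.

Measured in a functional assay on the whole organism (strain STD-dd) with Mus musculus as the target, in the maximal electroshock model, with a stated time of 2 h; on this read-out higher numbers stand for an effect only at larger amounts of compound and lower numbers for an effect already at smaller amounts:
compound 1 `CNS(=O)(=O)Cc1noc2ccccc12` gives 23 mg/kg
compound 2 `CC(C)NS(=O)(=O)Cc1noc2ccccc12` gives 56 mg/kg
compound 3 `NS(=O)(=O)Cc1noc2ccc(F)cc12` gives 15 mg/kg

Compound 3 holds the lowest of the three numbers in this assay; its nearest neighbour is compound 1, within the scatter, and compound 2 lies beyond the scatter from it. Compound 4 `CCNS(=O)(=O)Cc1noc2ccc(F)cc12` differs from compound 3 by ethyl in place of hydrogen on a sulfonamide nitrogen. Among the compounds with values here, the one step that bears on this change is a 2.4-fold higher number from compound 1 to compound 2 (0.39 log units; beyond the scatter), a growth of the group on the same nitrogen; it was modest and raised the number. Compound 4 is therefore expected to show a modest rise of similar size, a 1.7-fold higher number from compound 3 to compound 4 (0.22 log units; within the scatter), and is estimated at 25 mg/kg in this assay, within a range of 12 mg/kg to 50 mg/kg.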

Compound 4, dose for half-maximal effect: 32 mg/kg
Compound 4: the middle estimate sits 1.3-fold (0.11 log units) below what was measured; the measured number falls inside the stated range.
By their numbers in this assay, from the lowest: compounds 3, 1, 4 and 2 (each within the scatter of the next, the first and the last beyond it).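

In this assay, within the data shown here, the step of a 2.1-fold higher number from compound 3 to compound 4 (0.33 log units; beyond the scatter) shows that replacing hydrogen on the sulfonamide nitrogen with ethyl already moves the number, whereas the earlier step compared only two alkyl groups on that nitrogen. Both steps at this position are modest and raise the number, and they do so on two different cores. No measurement at hand accounts for this rise.

On these data alone, how a longer chain such as butyl on the sulfonamide nitrogen would read remains open. So does the effect of a carboxylic acid at the end of the ethyl group.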